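Demethylation at sulfur in a quinazoline-free series of cytotoxic agents

A few compounds are considered here, and "the series" means these few. Any claim that something is new, unique, unknown or untested is made for them only; others in the source may bear on it.

Measured compounds:
compound 1 `COc1ccc(CNc2nc([SeH])nc3ccccc23)cc1` — 7110 nM
compound 2 `Sc1nc(NCc2ccccc2)c2ccccc2n1` — 15200 nM
compound 3 `COc1ccc(CNc2nc(SC)nc3ccccc23)cc1` — 93700 nM

In a functional assay on HTB-54 cells (Homo sapiens) for cytotoxicity, read by MTT assay, with a stated time of 72 h (on this read-out higher numbers stand for weaker inhibition of growth and lower numbers for stronger inhibition of growth), compound 3 stands with the highest number of the three, above compound 2 and further still above compound 1, both gaps beyond the scatter. Compound 4 `COc1ccc(CNc2nc(S)nc3ccccc23)cc1` is compound 3 with one change, (hydrogen in place of methyl on a sulfur), that is, methylsulfanyl to sulfanyl.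

For the measured compounds named here, no measured step reproduces this exact change. Going by the values given here, the only step that bears on it is a 13-fold higher number from compound 1 to compound 3 (1.12 log units; beyond the scatter), where a methylsulfanyl group entered in place of one selenium atom and the number rose sharply. Compound 2, which carries a sulfanyl group but differs from compound 3 in two places, gives a number well below that of compound 3. Both observations point the same way: removing the methyl from sulfur is expected to lower the number, and the expected step of a 6.2-fold lower number from compound 3 to compound 4 (0.80 log units; beyond the scatter) is toward stronger inhibition of growth, with a size near the gap between compound 3 and compound 2. Compound 4 is therefore estimated at 15000 nM, within a range from 5000 nM to 50000 nM.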

Compound 4, concentration for 50% growth inhibition: 13500 nM
Beside the measured number, compound 4's estimate is 1.1-fold (0.05 log units) above it, within the range that was stated.
By their numbers in this assay, from the lowest: compounds 1, 4 and 2 (each within the scatter of the next, the first and the last beyond it); then compound 3.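

With the measurement of compound 4, the sulfur position in this assay has a direct reading: hydrogen in place of methyl on a sulfur gives (a 6.9-fold lower number from compound 3 to compound 4 (0.84 log units; beyond the scatter)), so the methylsulfanyl and sulfanyl forms stand apart by more than the scatter. The two other changes do not separate their pairs, since methoxy in place of hydrogen on an aromatic carbon gives (a 1.1-fold lower number from compound 2 to compound 4 (0.05 log units; within the scatter)) and one sulfur atom in place of one selenium atom gives (a 1.9-fold higher number from compound 1 to compound 4 (0.28 log units; within the scatter)), which means that the earlier step (a 13-fold higher number from compound 1 to compound 3 (1.12 log units; beyond the scatter)) now reads mainly as the methyl on sulfur and not as the exchange of selenium for sulfur. Nothing among the data shown explains any of these steps.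

Open, as far as these compounds go, is whether an ethyl group or a longer chain on the sulfur would stay with compound 3, and whether an amine in place of the sulfanyl group would stay with compound 4. Also open, from the compounds shown here alone, is whether methoxy and hydrogen on the aromatic carbon would stay as close together when the sulfur carries a methyl group.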